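This account rests on a few compounds, and the source may have more. Where it says the series, first, only, none or still open, it means among the compounds named here.

In an ADME assay on HEK293 cells (Homo sapiens) for cytotoxicity, read by CCK-8 assay, with a stated time of 48 h (on this read-out higher numbers stand for weaker inhibition and lower numbers for stronger inhibition), compound 1 `COc1ccc(/C=C\c2cc(OC)c(OC)c(OC)c2)cc1OCc1ccc(CNCCO)cc1` gives > 50000 nM, which is a limit of the assay and not a number. In this assay, among the compounds with values here, compound 2 `COc1ccc(/C=C\c2cc(OC)c(OC)c(OC)c2)cc1OCc1ccc(CN2CCCCC2C(=O)NCCNC(=O)OC(C)(C)C)cc1` reads 48000 nM, the only true number so far. Compound 3 `COc1ccc(/C=C\c2cc(OC)c(OC)c(OC)c2)cc1OCc1ccc(CN2CC[C@@H](C(=O)O)C2)cc1` keeps the core of compound 1 and changes one group: 3-carboxypyrrolidin-1-yl in place of (2-hydroxyethyl)amino on a saturated chain carbon bound to an aromatic carbon. Here 3-carboxypyrrolidin-1-yl takes the place of (2-hydroxyethyl)amino on a saturated chain carbon bound to an aromatic carbon. Within the data shown here, no step between measured compounds is available to size this change, so the expectation rests on the two readings alone, with compound 2 at 48000 nM as the nearest number. The step of a number no higher from compound 1 to compound 3 (the limit leaves the size open) is expected to stay within the usual scatter, with no direction foreseen. For compound 3 the estimated value is 50000 nM, with an expected range of 25000 nM to 100000 nM, and the assay may well report only a limit.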

Compound 3, half-maximal inhibitory concentration: 27000 nM
Beside the measured number, compound 3's estimate is 1.9-fold (0.27 log units) above it; the measured number falls inside the stated range.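

In this assay, within the data shown here, 3-carboxypyrrolidin-1-yl in place of (2-hydroxyethyl)amino on a saturated chain carbon bound to an aromatic carbon gives the first step that can be read at this place: an at least 1.8-fold lower number from compound 1 to compound 3 (0.26 log units; that floor lies within the scatter). Compound 1 gives > 50000 nM, which is a limit of the assay and not a number. The step therefore has a floor but no known size, and that floor does not show a change beyond the scatter, because one end of it rests on a limit: the limit of > 50000 nM in this assay, at which 1 of the 3 values shown sits.

The compounds shown leave open whether any difference would follow the ring or the carboxylic acid, as they include neither a plain pyrrolidin-1-yl group nor a methyl ester of that acid. They also leave open how the opposite configuration at the stereocentre of 3-carboxypyrrolidin-1-yl would read.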